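The source may report more compounds than this note shows. Statements on the series, on what has been measured and on what is new or still open speak of the compounds shown alone.

In a functional assay on the whole organism (strain Sprague-Dawley) for inhibition, with Rattus norvegicus as the target, read by paw edema, with stated times of 30 min and 2 h, at a dose of 80 mg/kg by the oral route (on this read-out lower numbers stand for less inhibition and higher numbers for more inhibition at the one dose given (going by the name of the read-out)), compound 1 `Cc1nc2ccccc2c(=O)n1NC(=O)NC1CCCCC1` gives 41.9%, compound 2 `Cc1nc2ccccc2c(=O)n1NC(=O)NC(C)(C)C` gives 29.8%, and compound 3 `CC(C)(C)NC(=O)Nn1c(CO[N+](=O)[O-])nc2ccccc2c1=O` gives 14.1%, the lowest of the three numbers, with every step to the other two beyond the usual scatter. Two single changes connect these compounds: a number 12.1 percentage points lower from compound 1 to compound 2 (beyond the scatter), and a number 15.7 percentage points lower from compound 2 to compound 3 (beyond the scatter). Compound 4 `O=C(NC1CCCCC1)Nn1c(CO[N+](=O)[O-])nc2ccccc2c1=O` differs from compound 3 by one change: cyclohexyl in place of tert-butyl on an amide-type nitrogen. This is the exact reverse of the change seen between compound 1 and compound 2, so a rise of roughly that size is expected, while the nitrooxy step carries no information on it. The expected step is a number 11.9 percentage points higher from compound 3 to compound 4 (beyond the scatter). The estimate for compound 4 is 26%, within a range from 14% to 40%.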

Compound 4, a percentage reported as inhibition, in the whole organism at one dose (the size of the read-out at that dose, not a potency): 18.7%
Compound 4: the middle estimate sits 7.3 percentage points above what was measured; the measured number falls inside the stated range.
By their numbers in this assay, from the lowest: compounds 3 and 4 (each within the scatter of the next); then compound 2; then compound 1.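

With the nitrooxy group present, cyclohexyl in place of tert-butyl on the amide-type nitrogen gives a number 4.6 percentage points higher from compound 3 to compound 4 (within the scatter), so in this assay this swap no longer separates the two groups, although this step and the earlier one still agree: the same change on two cores in this assay, a number 12.1 percentage points lower (beyond the scatter) from compound 1 to compound 2 and a number 4.6 percentage points lower (within the scatter) from compound 4 to compound 3, 7.5 percentage points apart, within the scatter of two such steps. Putting nitrooxy in place of hydrogen with cyclohexyl on that nitrogen gives a number 23.2 percentage points lower from compound 1 to compound 4 (beyond the scatter), so this change now lowers the number with either group there: the same change on two cores in this assay, a number 15.7 percentage points lower (beyond the scatter) from compound 2 to compound 3 and a number 23.2 percentage points lower (beyond the scatter) from compound 1 to compound 4, 7.5 percentage points apart, within the scatter of two such steps.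

Still open, going by these compounds, is how a phenyl or a longer chain on this nitrogen would read, and whether an amine or a carboxylic acid in place of nitrooxy would also lower the number.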